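Amino for chloro on the shared core of compound 1

The compounds below may be only part of what the source reports. "The series", "measured", "known", "first", "only" and "open" are said of these compounds alone.

Compound 1: `ClCc1cccc(Cn2cnc3c(Cl)nc(Cl)nc32)c1`, 14100 nM
Compound 2: `ClCc1cccc(Cn2cnc3nc(Cl)nc(Cl)c32)c1`, 460 nM

In a functional assay on SF-539 cells (Homo sapiens) for cytotoxicity, read by sulforhodamine B assay, with a stated time of 48 h (a higher number here means a weaker inhibitor of growth, a lower number a stronger inhibitor of growth), compound 1 gives 14100 nM, and compound 2 gives 460 nM. Compound 1 thus has the highest number of the two, and the gap to compound 2 lies beyond the scatter, so compound 1 is the weaker growth inhibitor of the pair. Among the compounds with values here, the two measured compounds differ in how the substituents are arranged on the shared core, and no single-point step connects them.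

Compound 3 is `Nc1nc(Cl)c2ncn(Cc3cccc(CCl)c3)c2n1`. It differs from compound 1 in one place: amino in place of chloro on an aromatic carbon. The amino group sits on an aromatic carbon between two ring nitrogen atoms, meta to a chloro group, meta to a fused ring and para to a fused ring. Within the data shown here, no measured pair shows the effect of this exchange, so the direction is open. The step from compound 1 to compound 3 is expected to stay modest, a 1.4-fold lower number from compound 1 to compound 3 (0.15 log units; within the scatter), and compound 3 is estimated at 10000 nM, with a range from 2000 nM to 50000 nM.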

Compound 3, concentration for total growth inhibition: 20400 nM
Compound 3: middle estimate off by 2.0-fold (0.31 log units), on the low side; low and high end bracket the measured number.
By their numbers in this assay, from the lowest: compound 2; then compounds 1 and 3 (each within the scatter of the next).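

In this assay, within the data shown here, amino in place of chloro on the aromatic carbon between two ring nitrogen atoms gives a 1.4-fold higher number from compound 1 to compound 3 (0.16 log units; within the scatter), the first reading of this exchange at this position. Chloro at this place is therefore not needed for compound 3 to match compound 1 in this read-out, and the hydrogen-bond donor that enters with the amino group does not separate the two compounds here. Nothing measured here accounts for why the two groups read alike.

Going by these compounds, it remains open whether this tolerance extends to other groups at this position, such as a methoxy group, a methylamino group or a dimethylamino group, and whether any of them would move the number beyond the scatter. On these data alone, it also remains open whether the same amino for chloro exchange would read alike on the differently arranged core of compound 2, and how the chloro group that stays on the core of compound 3 would respond to an amine in its place.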